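A few compounds are considered here, and "the series" means these few. Any claim that something is new, unique, unknown or untested is made for them only; others in the source may bear on it.

In a functional assay on SK-OV-3 cells (Homo sapiens) for cytotoxicity, read by MTT assay, with a stated time of 48 h (on this read-out higher numbers stand for weaker inhibition and lower numbers for stronger inhibition), compound 1 `C=CCn1c(-c2cc(OC)c(OC)cc2COCOC)cc2ccccc2c1=O` gives 37700 nM and compound 2 `C=CCn1c(-c2cc(OC)c(OC)cc2C=C)cc2ccccc2c1=O` gives 35500 nM, so the two stand level within the scatter. Compound 3 `COCOCc1cc(OC)c(OC)cc1-c1cc2ccccc2c(=O)[nH]1` departs from compound 1 elsewhere: hydrogen in place of allyl on an aromatic nitrogen. Among the compounds with values here, the only measured step, a 1.1-fold lower number from compound 1 to compound 2 (0.03 log units; within the scatter), concerns a different group and stays within the scatter, so it bears only loosely on this change and gives no direction. The estimated step is therefore a 1.1-fold higher number from compound 1 to compound 3 (0.03 log units; within the scatter), which is expected to be none beyond the scatter. In this assay the expected value for compound 3 is 40000 nM, with an estimated range from 15000 nM to 100000 nM.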

Compound 3, half-maximal inhibitory concentration: 87700 nM
Compound 3: middle estimate off by 2.2-fold (0.34 log units), on the low side, within the range that was stated.
By their numbers in this assay, from the lowest: compounds 2 and 1 (each within the scatter of the next); then compound 3.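

Hydrogen in place of allyl on the aromatic nitrogen gives a 2.3-fold higher number from compound 1 to compound 3 (0.37 log units; beyond the scatter) in this assay. Unlike the earlier vinyl change on an aromatic carbon, this change goes beyond the scatter, so the allyl on this nitrogen goes with modestly stronger inhibition than hydrogen. Nothing available explains this difference. Going by these compounds, whether a methyl group, a benzyl group or a longer chain on this nitrogen would match allyl remains open. So does whether the step would hold with vinyl in place of (methoxymethoxy)methyl.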